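The source may report more compounds than this note shows. Statements on the series, on what has been measured and on what is new or still open speak of the compounds shown alone.

Measured compounds:
- Compound 1 `O=C(/C=C/c1cccc(OCc2ccccc2)c1)c1ccc(Br)cc1` gives 1800 nM in a functional assay on A2780 cells (Homo sapiens) for cytotoxicity, read by MTT assay, with a stated time of 68 h; on this read-out lower numbers stand for stronger inhibition and higher numbers for weaker inhibition.
- Compound 2 `COc1ccc(C(=O)/C=C/c2cccc(OCc3ccccc3)c2)cc1` gives 38100 nM in this assay.
- Compound 3 `O=C(/C=C/c1cccc(OCc2ccccc2)c1)c1ccc(Cl)cc1Cl` gives 21400 nM in this assay.

Among these three numbers compound 2 stands highest, which on this read-out means the weakest inhibition; compound 3 sits close to it, within the scatter (a 1.8-fold lower number from compound 2 to compound 3 (0.25 log units; within the scatter)), while compound 1 is far lower (a 21-fold higher number from compound 1 to compound 2 (1.33 log units; beyond the scatter)).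

Compound 4 `O=C(/C=C/c1cccc(OCc2ccccc2)c1)c1ccc(Cl)cc1` is not yet measured. It differs from compound 2 in one place: chloro in place of methoxy on an aromatic carbon. For the measured compounds named here, the step that bears on this change is the one from compound 1 to compound 2, where a methoxy replaced a bromo on the same aromatic carbon and the number rose sharply (a 21-fold higher number from compound 1 to compound 2 (1.33 log units; beyond the scatter)). Chloro, like bromo, is a halogen, so reversing that kind of exchange is expected to bring the number well down again, beyond the scatter, in this assay.

Compound 4 is therefore expected to give about 2500 nM, in a range from 900 nM to 7000 nM, a step of a 15-fold lower number from compound 2 to compound 4 (1.18 log units; beyond the scatter).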

Compound 4, half-maximal inhibitory concentration: 56400 nM
Estimate against measurement, compound 4: 23-fold (1.35 log units) below; measured number above the stated range.
By their numbers in this assay, from the lowest: compound 1; then compounds 3, 2 and 4 (each within the scatter of the next, the first and the last beyond it).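

Chloro and methoxy at this aromatic carbon cannot be told apart in this assay (a 1.5-fold higher number from compound 2 to compound 4 (0.17 log units; within the scatter)), so a halogen here does not by itself give a low number. Bromo and chloro at this same carbon are far apart (a 31-fold higher number from compound 1 to compound 4 (1.50 log units; beyond the scatter)), which leaves compound 1 alone among the four with a low number and sets compound 3 and compound 4 against any rule that halogens here behave alike. Taking away the extra chloro of compound 3 changes the number only modestly (a 2.6-fold higher number from compound 3 to compound 4 (0.42 log units; beyond the scatter)), and neither of these chlorinated compounds comes near compound 1.

Nothing measured here explains why bromo and chloro part so widely. Going by these compounds, how fluoro, iodo or an amine at this carbon would compare remains open.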